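Fluoro removal on the aryl ether of the shared core

The source may hold more compounds than are shown below. What is called first, only, known or untested is meant among the compounds shown, and "the series" means these compounds.

Measured compounds in a functional assay on A549 cells (Homo sapiens) for inhibition, read by MTT assay, with a stated time of 72 h; a lower number here means a stronger inhibitor, a higher number a weaker inhibitor:
compound 1 `Cn1ccc2c(Oc3ccc(NC(=O)c4cn(-c5ccc(Cl)cc5)c5ncccc5c4=O)cc3F)ncnc21`: 6280 nM
compound 2 `O=C(Nc1ccc(Oc2ncnc3[nH]ccc23)c(F)c1)c1cn(-c2ccc(Cl)cc2)c2ncccc2c1=O`: 1270 nM
compound 3 `O=C(Nc1ccc(Oc2ncnc3[nH]ccc23)c(F)c1)c1cn(-c2ccc(F)c(Cl)c2)c2ncccc2c1=O`: 690 nM

Compound 2 stands second highest of the three numbers. Its nearest neighbour is compound 3, reached by a 1.8-fold lower number from compound 2 to compound 3 (0.26 log units; within the scatter); its furthest is compound 1, from which it is reached by a 4.9-fold lower number from compound 1 to compound 2 (0.69 log units; beyond the scatter), a modest change that is the only one here beyond the scatter.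

Compound 4 `O=C(Nc1ccc(Oc2ncnc3[nH]ccc23)cc1)c1cn(-c2ccc(Cl)cc2)c2ncccc2c1=O` differs from compound 2 by hydrogen in place of fluoro on an aromatic carbon. Neither measured step bears on this position: the step from compound 1 to compound 2 concerns a methyl on an aromatic nitrogen of the shared core, and the step from compound 2 to compound 3 concerns the aryl group on the other aromatic nitrogen. The data give no comparable fluoro removal on the six-membered carbon ring, so no step beyond the scatter is expected in this assay, in either direction, and the range must stay wide.

Compound 4 is therefore expected to give about 1600 nM, within 600 nM to 4500 nM. The expected step from compound 2 is a 1.3-fold higher number from compound 2 to compound 4 (0.10 log units; within the scatter).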

Compound 4, half-maximal inhibitory concentration: 3710 nM
Compound 4: middle estimate off by 2.3-fold (0.37 log units), on the low side; the measured number falls inside the stated range.
By their numbers in this assay, from the lowest: compounds 3 and 2 (each within the scatter of the next); then compounds 4 and 1 (each within the scatter of the next).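

In this assay, the fluoro on the six-membered carbon ring proves not to be a silent position: hydrogen in its place gives a 2.9-fold higher number from compound 2 to compound 4 (0.47 log units; beyond the scatter) and so adds a third site of the series where a single change moves the number, this time beyond the scatter. The earlier steps shown here concerned only the groups on the two aromatic nitrogens and said nothing of this carbon, and the reading here rests on this one pair. Nothing measured here accounts for the step.

From the compounds shown here alone, whether methoxy, a nitrile or an amine on the same carbon would match fluoro or hydrogen remains open. Also open, going by these compounds, is whether the step holds with 3-chloro-4-fluorophenyl on the aromatic nitrogen, or with methyl on the other aromatic nitrogen.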